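This account rests on a few compounds, and the source may have more. Where it says the series, first, only, none or still open, it means among the compounds named here.

The measured compounds are:

compound 1, `COc1ccc(N2CCN(CN3C(=O)/C(=N\NC(=S)NO)c4cc(F)ccc43)CC2)cc1`, 260000 nM
compound 2, `COc1ccc(N2CCN(CN3C(=O)/C(=N\NC(=S)NO)c4cc(Cl)ccc43)CC2)cc1`, 279000 nM
compound 3, `CCn1cc(C(=O)O)c(=O)c2cc(F)c(N3CCN(CN4C(=O)/C(=N\NC(=S)NO)c5cc(Cl)ccc54)C(C)C3)c(F)c21`, 209000 nM

All three were tested in an ADME assay on MT4 cells (Homo sapiens) for cytotoxicity, read by spectrophotometry, with a stated time of 5 days; on this read-out higher numbers stand for lower toxicity in this test and lower numbers for higher toxicity in this test. Compound 1 and compound 2 share one core and differ in a single place: fluoro in place of chloro on an aromatic carbon. For this pair the measured step is a 1.1-fold lower number from compound 2 to compound 1 (0.03 log units; within the scatter), so the two values are indistinguishable within the scatter of the test, and neither compound can be called less or more toxic than the other.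

Compound 3 carries a different core. How its core differs from that of compound 2 is not broken down here; what the data show is that compound 3 and compound 2 give values within the scatter of each other in this assay, as do compound 3 and compound 1.

The compound not yet measured is compound 4, `CCn1cc(C(=O)O)c(=O)c2cc(F)c(N3CCN(CN4C(=O)/C(=N\NC(=S)NO)c5cc(F)ccc54)C(C)C3)c(F)c21`. It stands to compound 3 as compound 1 stands to compound 2: fluoro in place of chloro on an aromatic carbon. The place of the change is described in the same words for both pairs, so this is the same change made on a second core, and it appears in two pairs among the compounds shown.

He expects the step from compound 3 to compound 4 to be small, about a 1.0-fold lower number from compound 3 to compound 4 (0.02 log units; within the scatter), because the same change gave only a 1.1-fold lower number from compound 2 to compound 1 (0.03 log units; within the scatter) on the first core. On that basis compound 4 is estimated to give 200000 nM in this assay, with a likely range from 120000 nM to 330000 nM.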

Compound 4, half-maximal cytotoxic concentration: 187000 nM
Compound 4: the middle estimate sits 1.1-fold (0.03 log units) above what was measured; the measured number falls inside the stated range.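

In this assay the new step is a 1.1-fold lower number from compound 3 to compound 4 (0.05 log units; within the scatter), so fluoro in place of chloro on an aromatic carbon leaves the two values within the scatter of each other on this second core, as it did on the first. Set side by side, the two steps agree: the same change on two cores in this assay, a 1.1-fold lower number (0.03 log units; within the scatter) from compound 2 to compound 1 and a 1.1-fold lower number (0.05 log units; within the scatter) from compound 3 to compound 4, 1.0-fold (0.02 log units) apart, within the scatter of two such steps. This shows that on these two cores the change carries over consistently as a step too small to read in this test, but it does not show that the change has any real effect on toxicity here, and two pairs say nothing about how it would behave on a third core or in a different test.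

The compounds shown carry only chloro or fluoro at this place, which leaves open whether a bromo, nitro or methyl group there would give a step beyond the scatter. They also leave open whether the same agreement between steps would hold with an ester or an amide in place of the carboxylic acid of compound 3 and compound 4.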